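The source may report more compounds than this note shows. Statements on the series, on what has been measured and on what is new or still open speak of the compounds shown alone.

Measured so far, in a physicochemical assay for solubility, read by HPLC, with a stated time of 4 h, at pH 2; a higher number here means a more soluble compound, a lower number a less soluble compound:
Compound 1, `Cc1cc(/C=C/C#N)cc(C)c1Oc1cc(Nc2ccc(C#N)cc2)c(N)cc1C(=O)NCCCO`, gives 19.9 ug/mL.
Compound 2, `Cc1cc(/C=C/C#N)cc(C)c1Oc1cc(Nc2ccc(C#N)cc2)c(N)cc1C(=O)N1CC1`, gives 94.2 ug/mL.
Compound 3, `Cc1cc(/C=C/C#N)cc(C)c1Oc1cc(Nc2ccc(C#N)cc2)c(N)cc1C(=O)OCCC#N`, gives 0.94 ug/mL.

Compound 3 has the lowest solubility of the three. Its nearest neighbour is compound 1, reached by the step of a 21-fold lower number from compound 1 to compound 3 (1.33 log units; beyond the scatter); the furthest is compound 2, reached by the step of a 100-fold lower number from compound 2 to compound 3 (2.00 log units; beyond the scatter). Both steps are well beyond the scatter, so compound 3 stands clearly apart at the bottom of this small set.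

Compound 4, `CNC(=O)c1cc(N)c(Nc2ccc(C#N)cc2)cc1Oc1c(C)cc(/C=C/C#N)cc1C`, has not yet been measured. It differs from compound 3 in one place: methylamino in place of 2-cyanoethoxy on a carbonyl carbon. The ester group of compound 3 is thereby replaced by an amide, as found in compound 1 and compound 2.

The measured steps that bear on this change are the ones at the same position. Going from either amide to the ester lowered the number sharply, as a 21-fold lower number from compound 1 to compound 3 (1.33 log units; beyond the scatter) and a 100-fold lower number from compound 2 to compound 3 (2.00 log units; beyond the scatter) show, while the two amides differ from each other by less, a 4.7-fold higher number from compound 1 to compound 2 (0.68 log units; beyond the scatter). Returning from the ester to an amide, the expectation is a large rise, a 32-fold higher number from compound 3 to compound 4 (1.50 log units; beyond the scatter). Compound 4 is therefore estimated at 30 ug/mL, with a range from 8 ug/mL to 120 ug/mL.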

Compound 4, solubility: 44.7 ug/mL
Estimate against measurement, compound 4: 1.5-fold (0.17 log units) below; the range from low to high includes it.
By their numbers in this assay, from the lowest: compound 3; then compound 1; then compound 4; then compound 2.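

In this assay, methylamino on the carbonyl carbon in place of 2-cyanoethoxy gives a 48-fold higher number from compound 3 to compound 4 (1.68 log units; beyond the scatter) and so a third amide now stands far above the single ester at this position. Among the amides, compound 4 falls in the middle, with a 2.1-fold lower number from compound 2 to compound 4 (0.32 log units; beyond the scatter) and a 2.2-fold higher number from compound 1 to compound 4 (0.35 log units; beyond the scatter) so the differences among these three are modest, though still beyond the scatter, and all are much smaller than the gap from any of them to compound 3. Nothing shown here gives a measured reason for that gap or for the order among the amides.

Compound 1 and compound 4 differ in both the length of the chain on the amide nitrogen and its end hydroxyl group, so these compounds cannot separate what each contributes; a plain propylamino amide would bear on that question. On these data alone, it also remains open how this position would read with a primary amide, with a chain ending in a dimethylamino group, or with a carboxylic acid in place of the amide.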